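Rat plasma stability: hydroxy to phenyl on the ester ring

The source may report more compounds than this note shows. Statements on the series, on what has been measured and on what is new or still open speak of the compounds shown alone.

Measured in an ADME assay on a cell-free system (plasma, Homo sapiens) for metabolic stability, with Plasma (Rattus norvegicus) as the target, read by HPLC, at pH 7.4; on this read-out lower numbers stand for a shorter-lived compound and higher numbers for a longer-lived compound:
- compound 1 `CC(=O)Oc1ccccc1C(=O)O[C@H]1CO[C@H]2[C@@H]1OC[C@H]2OC(=O)c1ccc(O)cc1`: 0.0198 h
- compound 2 `CC(=O)Oc1ccccc1C(=O)O[C@H]1CO[C@H]2[C@@H]1OC[C@H]2OC(=O)c1cccc(C)c1`: 0.165 h
- compound 3 `COc1ccccc1C(=O)O[C@@H]1CO[C@H]2[C@@H]1OC[C@@H]2OC(=O)c1ccccc1OC(C)=O`: 0.0578 h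

Compound 1 holds the lowest number of the three, with compound 3 nearest and compound 2 furthest. Compound 4 `CC(=O)Oc1ccccc1C(=O)O[C@H]1CO[C@H]2[C@@H]1OC[C@H]2OC(=O)c1ccc(-c2ccccc2)cc1` is not yet measured in this assay; against compound 1 it differs as phenyl in place of hydroxy on an aromatic carbon. For the measured compounds named here, two measured steps bear on this, both leaving the 4-hydroxyphenyl ester of compound 1: an 8.3-fold higher number from compound 1 to compound 2 (0.92 log units; beyond the scatter) and a 2.9-fold higher number from compound 1 to compound 3 (0.47 log units; beyond the scatter). Each change away from the hydroxy-bearing ring raised the number beyond the scatter, the 3-methylphenyl case more than the 2-methoxyphenyl case; the step between them, a 2.9-fold lower number from compound 2 to compound 3 (0.46 log units; beyond the scatter), shows the size depends on which group enters. Going by the values given here, no measured step puts a phenyl at this aromatic carbon, so the size is uncertain, but a rise of the same order as those two steps is expected. Compound 4 is therefore estimated at 0.2 h, within 0.06 h to 0.7 h, which would mean an expected 10-fold higher number from compound 1 to compound 4 (1.00 log units; beyond the scatter).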

Compound 4, half-life: > 0.333 h
Compound 4 ended at the assay's limit; the forecaster's own chance of this, stated with the estimate: 5%; at least 1.6-fold (0.22 log units) between middle value and limit.
By their numbers in this assay, from the lowest: compound 1; then compound 3; then compound 2. At a limit, above all of these: compound 4.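

In this assay compound 4 gives a limit and not a number: the limit of > 0.333 h in this assay, at which 1 of the 4 values shown sits. At this aromatic carbon, para to a large group, phenyl in place of hydroxy gives an at least 16-fold higher number from compound 1 to compound 4 (1.22 log units; beyond the scatter), the largest step from compound 1 shown, so a six-membered aromatic ring of carbon only at this place goes with a longer half-life, not a shorter one. Among the other esters, 4-phenylphenyl gives an at least 5.7-fold higher number from compound 3 to compound 4 (0.76 log units; beyond the scatter), while an at least 2.0-fold higher number from compound 2 to compound 4 (0.30 log units; that floor lies within the scatter) leaves the margin over the 3-methylphenyl ester unsettled.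

Going by these compounds, whether the rise belongs to the loss of hydroxy or to the entry of phenyl stays open, as does the true half-life of compound 4. On these data alone, what an amine or a carboxylic acid would give at this aromatic carbon also remains open.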